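The compounds below may be only part of what the source reports. "The series", "measured", "known", "first", "only" and "open" are said of these compounds alone.

Of the compounds shown here, three built on related cores have been tested in a functional assay on PC-12 cells (Rattus norvegicus) for cytotoxicity, read by MTT assay, with stated times of 3 h and 2 h, tested at 5 uM; on this read-out lower numbers stand for a weaker effect and higher numbers for a stronger effect at the one concentration tested. Compound 1 `CCOC(=O)c1cc2ccc(OCCCn3cc(CNC(=O)CCCCC4CCSS4)nn3)cc2oc1=O` gives 32.4% in this assay. Going by the values given here, compound 2 `O=C(CCCCC1CCSS1)NCc1cn(CCCOc2ccc3cc(-c4ccccc4)c(=O)oc3c2)nn1`, in which the only change is phenyl in place of ethoxycarbonyl on an aromatic carbon, gives 29.8% in this assay. The step between these two, a number 2.6 percentage points lower from compound 1 to compound 2 (within the scatter), is small enough to fall within the usual spread of repeated runs, so the two numbers cannot be told apart. Compound 3 `CCOC(=O)c1cc2ccc(OCCCCCn3cc(CNC(=O)CCCCC4CCSS4)nn3)cc2oc1=O` gives 36.4% in this assay. Compound 3 and compound 1 differ in more than one place, and the difference between the two cores is not broken down here. The numbers of compound 3, compound 1 and compound 2 all lie within the usual spread of one another, so none of the three can be called stronger or weaker than the others.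

Compound 4 `O=C(CCCCC1CCSS1)NCc1cn(CCCCCOc2ccc3cc(-c4ccccc4)c(=O)oc3c2)nn1` has not yet been measured. Compared with compound 3 it carries phenyl in place of ethoxycarbonyl on an aromatic carbon, which is the same change as the one from compound 1 to compound 2, made at the same place on the core. The change in this assay from compound 3 to compound 4 is therefore expected to be about a number 2.4 percentage points lower from compound 3 to compound 4 (within the scatter), because the same change gave a number 2.6 percentage points lower from compound 1 to compound 2 (within the scatter). On that basis compound 4 is estimated to give about 34% in this assay, expected to fall between 24% and 44%.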

Compound 4, a percentage reported as activity, at one concentration (the size of the read-out at that concentration, not a potency): 28%
The estimate for compound 4 lay 6 percentage points above the measured number; the measured number falls inside the stated range.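

Swapping ethoxycarbonyl for phenyl on the core of compound 3 gives, in this assay, a number 8.4 percentage points lower from compound 3 to compound 4 (within the scatter). Set beside the same swap on the core of compound 1, the two steps cannot be told apart: the same change on two cores in this assay, a number 2.6 percentage points lower (within the scatter) from compound 1 to compound 2 and a number 8.4 percentage points lower (within the scatter) from compound 3 to compound 4, 5.8 percentage points apart, within the scatter of two such steps The two pairs therefore fit the idea that this swap carries over from one core to the other, but they do not show that it has a fixed size, or that it has any real effect on this read-out at all, as each step on its own cannot be separated from the ordinary spread of repeated runs, and two pairs at a single concentration are a thin basis for any rule.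

The compounds shown place only ethoxycarbonyl and phenyl on this aromatic carbon, so it remains open whether a carboxylic acid, an amine or a small alkyl group there would shift the number by more than the scatter. It also remains open whether a still longer chain on the ring oxygen would do so, and whether any of these compounds would show a stronger or weaker effect at other concentrations.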